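A few compounds are considered here, and "the series" means these few. Any claim that something is new, unique, unknown or untested is made for them only; others in the source may bear on it.

Compound 1 `COc1ccc(/C=C2/S/C(=N/c3ccccc3)N(Cc3ccncc3)C2=O)cc1` gives 31500 nM in a functional assay on MCF7 cells (Homo sapiens) for cytotoxicity, read by MTT assay, with a stated time of 48 h; a lower number here means a stronger inhibitor, a higher number a weaker inhibitor.
Compound 2 `CN(C)c1ccc(/C=C2/S/C(=N/c3ccccc3)N(Cc3ccncc3)C2=O)cc1` gives 76300 nM in this assay.
Compound 3 `COc1ccc(OC)c(/C=C2/S/C(=N/c3ccccc3)N(Cc3ccncc3)C2=O)c1` gives 37000 nM in this assay.

Compound 2 stands at the highest number of the three: its gap to compound 3 is a 2.1-fold lower number from compound 2 to compound 3 (0.31 log units; beyond the scatter), and the other gap is a 2.4-fold higher number from compound 1 to compound 2 (0.38 log units; beyond the scatter). Compound 1 and compound 3 sit within the scatter of each other, so no order between them is claimed.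

Compound 4 `Cc1ccc(/C=C2/S/C(=N/c3ccccc3)N(Cc3ccncc3)C2=O)s1` has not been measured. It differs from compound 2 in one place: 5-methylthiophen-2-yl in place of 4-(dimethylamino)phenyl on a double-bonded chain carbon bound to a double-bonded ring carbon. Both steps that leave the 4-(dimethylamino)phenyl group of compound 2 for another aryl group on the same chain carbon, a 2.4-fold higher number from compound 1 to compound 2 (0.38 log units; beyond the scatter) reversed and a 2.1-fold lower number from compound 2 to compound 3 (0.31 log units; beyond the scatter), lowered the number by a modest amount beyond the scatter. Within the data shown here, the entering 5-methylthiophen-2-yl is neither of those groups, so the only reasonable guide is that moving away from compound 2 has so far given a modest lowering.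

Compound 4 is therefore expected to show a 1.9-fold lower number from compound 2 to compound 4 (0.28 log units; within the scatter) in this assay, a modest lowering. The estimated value for compound 4 is 40000 nM, with a range from 15000 nM to 100000 nM.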

Compound 4, half-maximal inhibitory concentration: 28700 nM
Beside the measured number, compound 4's estimate is 1.4-fold (0.14 log units) above it; the measured number falls inside the stated range.
By their numbers in this assay, from the lowest: compounds 4, 1 and 3 (each within the scatter of the next); then compound 2.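

In this assay, a third group now replaces 4-(dimethylamino)phenyl on the double-bonded chain carbon bound to a double-bonded ring carbon, with a 2.7-fold lower number from compound 2 to compound 4 (0.42 log units; beyond the scatter), and this time the entering group is a five-membered aromatic ring rather than a phenyl. The 5-methylthiophen-2-yl group cannot be told apart from the two methoxy-bearing phenyl groups, with a 1.1-fold lower number from compound 1 to compound 4 (0.04 log units; within the scatter) and a 1.3-fold lower number from compound 3 to compound 4 (0.11 log units; within the scatter), so compound 2 alone stands apart among the four. No evidence at hand bears on the reason for these numbers.

On these data alone, compound 2 is the only one of the four with an amine on its aryl group, so it remains open whether a primary amino or morpholine group there would give a similarly high number. Also open, as far as these compounds go, is how an unsubstituted thiophen-2-yl, a pyridyl or a carboxylic acid-bearing phenyl at this carbon would compare.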